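Amino for methoxy on the aryl ring of compound 3

This account rests on a few compounds, and the source may have more. Where it says the series, first, only, none or still open, it means among the compounds named here.

Measured so far in a functional assay on M14 cells (Homo sapiens) for antiproliferative activity, with a stated time of 72 h; on this read-out lower numbers stand for stronger inhibition and higher numbers for weaker inhibition:
compound 1, `C=CC[C@H]1C[C@]2([C@@H](C)Cc3ccc(OC)c(OC)c3)OCOC2=CC1=O`, gives 110 nM
compound 2, `C=CC[C@H]1C[C@]2([C@H](C)Cc3ccc(OC)c(OC)c3)OCOC2=CC1=O`, gives 300 nM
compound 3, `C=CC[C@H]1C[C@]2([C@@H](C)Cc3cc(OC)c(OC)cc3F)OCOC2=CC1=O`, gives 14 nM

Compound 3 stands at the lowest number of the three in this assay; its nearest neighbour is compound 1, and compound 2 stands furthest. Inverting one stereocentre gives a 2.7-fold higher number from compound 1 to compound 2 (0.44 log units; beyond the scatter), a modest step attributable to the fact that compounds 1 and 2 differ only in the configuration as drawn. Adding fluoro gives a 7.9-fold lower number from compound 1 to compound 3 (0.90 log units; beyond the scatter), the larger step of the two.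

Compound 4, `C=CC[C@H]1C[C@]2([C@@H](C)Cc3cc(N)c(OC)cc3F)OCOC2=CC1=O`, carries amino in place of methoxy on an aromatic carbon. Neither measured step touches this position or this kind of exchange: one changes configuration only, the other places fluoro on an aromatic carbon. For the measured compounds named here, no measured step therefore bears directly on the move from compound 3 to compound 4, and the size of the step is open. With the same aryl fluoro retained, compound 4 is expected to stay within a modest distance of compound 3, estimated as a 2.1-fold higher number from compound 3 to compound 4 (0.33 log units; beyond the scatter). The estimate for compound 4 in this assay is 30 nM, with a range from 8 nM to 120 nM.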

Compound 4, half-maximal inhibitory concentration: 29 nM
Beside the measured number, compound 4's estimate is 1.0-fold (0.01 log units) above it, within the range that was stated.
By their numbers in this assay, from the lowest: compound 3; then compound 4; then compound 1; then compound 2.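

In this assay, the methoxy group para to a fluoro group can be exchanged for amino at a modest cost: a 2.1-fold higher number from compound 3 to compound 4 (0.32 log units; beyond the scatter). For the compounds shown here, this is the first reading at this position, as the earlier steps concerned only a stereocentre and the addition of fluoro. The change replaces an oxygen-linked methyl with a single nitrogen and leaves the rest of compound 3 intact, but nothing measured here accounts for the size of the step.

From the compounds shown here alone, whether the step depends on the amino group itself remains open, and a hydroxyl, an acetamide or a dimethylamino group at this position would help to test that. Also open, going by these compounds, are whether the same exchange gives a similar step without the fluoro group, and what happens at the remaining methoxy group.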